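The compounds below may be only part of what the source reports. "The series", "measured", "known", "first", "only" and "open" are said of these compounds alone.

Measured so far:
Compound 1 `CCc1nc(-c2ccc(OC(F)(F)F)cc2OC)c(CC)nc1NC(CC)CC`: 0.217 h
Compound 2 `CCOc1nc(-c2ccc(Cl)cc2Cl)c(CC)nc1NC(CC)CC`: 2 h
Compound 3 `CCc1nc(-c2ccc(Cl)cc2Cl)c(CC)nc1NC(C1CC1)C1CC1`: 0.183 h

In an in vitro ADME assay on microsomes (Homo sapiens) for metabolic stability (on this read-out higher numbers stand for a longer-lived compound and lower numbers for a shorter-lived compound), compound 1, at 0.217 h, lies within the scatter of compound 3, at 0.183 h. Compound 2, at 2 h, stands far higher than compound 1. The unmeasured compound 4 `CCc1nc(-c2ccc(OC(F)(F)F)cc2OC)c(OC)nc1NC(CC)CC` has methoxy in place of ethyl on an aromatic carbon.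

For the measured compounds named here, no measured pair isolates this swap. Compound 2, at 2 h, carries ethoxy on the core but differs from compound 1 in more than one place, so it offers only a weak hint of a modest upward step in this assay. The expected change is a 2.3-fold higher number from compound 1 to compound 4 (0.36 log units; beyond the scatter), a small rise near the edge of the scatter. Compound 4 is estimated at 0.5 h, with an expected range of 0.17 h to 1.4 h.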

Compound 4, half-life: 0.867 h
The estimate for compound 4 lay 1.7-fold (0.24 log units) below the measured number, and the stated range covers the measured number.
By their numbers in this assay, from the lowest: compounds 3 and 1 (each within the scatter of the next); then compound 4; then compound 2.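

For the compounds shown here, this is the first clean reading of this position: in this assay, methoxy in place of ethyl on an aromatic carbon next to the ring nitrogen gives a 4.0-fold higher number from compound 1 to compound 4 (0.60 log units; beyond the scatter) with the rest of the molecule unchanged. Going by these compounds alone, the step is modest but beyond the scatter, so this single swap is enough to move the half-life, which no earlier pair could show. Nothing measured here explains the rise.

From the compounds shown here alone, it remains open whether a propoxy chain, an amine or a nitrile at this position would shift the half-life further. Going by these compounds, whether the same swap gives a similar rise with other groups elsewhere on the shared core also remains open.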